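The source may report more compounds than this note shows. Statements on the series, on what has been measured and on what is new or still open speak of the compounds shown alone.

Three compounds of the shared core have numbers in a functional assay on NUGC-3 cells (Homo sapiens) for antiproliferative activity, read by sulforhodamine B assay; a lower number here means a stronger inhibitor of growth, a higher number a weaker inhibitor of growth. Compound 1, `Cc1cc(C)c2sc(NC(=O)c3ccc(C(F)(F)F)cc3)nc2c1`, gives 1.4 ug/mL. Compound 2, `COc1cccc2sc(NC(=O)c3ccc(C#N)cc3)nc12`, returns only a limit in this assay, > 10 ug/mL. Compound 3, `O=C(Nc1ccccc1)Nc1nc2ccc(F)cc2s1`, likewise returns only a limit, > 10 ug/mL. Compound 2 thus stands at the limit of > 10 ug/mL in this assay, at which 2 of the 3 values shown sit, with no number of its own in this assay. Among the compounds with values here, no step between compounds that differ in a single place is available among the measured set, so nothing measured yet tells how a change of the group on the six-membered ring moves the value.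

Compound 4, `COc1cccc2sc(NC(=O)c3ccc([N+](=O)[O-])cc3)nc12`, is not yet measured in this assay. It differs from compound 2 in one place: nitro in place of cyano on an aromatic carbon. Both the leaving and the entering group carry no net charge and sit on the same aromatic carbon, and nothing in the measured values separates cyano from nitro, so no step beyond the scatter is expected in either direction. The estimated step that the limit leaves unreadable from compound 2 to compound 4 is therefore set against the limit rather than against a number. For compound 4 the estimate in this assay is 12 ug/mL, within 4 ug/mL to 40 ug/mL, with a fair chance that again only a limit is reported.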

Compound 4, concentration for 50% growth inhibition: > 10 ug/mL
Compound 4 gave a limit, no number; the forecaster's own chance of this, stated with the estimate: 65%; the middle value lies beyond the limit too.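

Compound 2 and compound 4 both return only a limit in this assay, so no step between them can be read: the limit of > 10 ug/mL in this assay, at which 3 of the 4 values shown sit.

The compounds shown leave open whether nitro in place of cyano changes growth inhibition at all, and where either compound's actual value lies.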